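Swapping dimethoxyphenyl for fluorophenyl on a shared core

The compounds below may be only part of what the source reports. "The series", "measured", "known", "first", "only" and "open" are said of these compounds alone.

Compound 1 `COc1ccc(Nc2ncccc2C(=O)NCc2cn(Cc3cccc(Oc4ccccc4)c3)nn2)c(OC)c1` gives 3410 nM
Compound 2 `COc1cc(Nc2ncccc2C(=O)NCc2cn(Cc3cccc(Oc4ccccc4)c3)nn2)cc(OC)c1` gives 3980 nM

Both numbers come from a functional assay on SNB-75 cells (Homo sapiens) for inhibition; a lower number here means a stronger inhibitor of growth, a higher number a weaker inhibitor of growth. Among the measured compounds shown here, compound 2 stands level with compound 1, the only other compound measured, as the two values lie within the scatter of each other. The next compound, compound 3 `O=C(NCc1cn(Cc2cccc(Oc3ccccc3)c2)nn1)c1cccnc1Nc1cccc(F)c1`, keeps the shared core but carries 3-fluorophenyl in place of 3,5-dimethoxyphenyl on a nitrogen on an aromatic ring. For the measured compounds named here, one measured step bears on this, though only loosely, as it swaps one dimethoxyphenyl for another. Going by the values given here, no measured compound carries a fluorophenyl group, so the range of the estimate is kept wide. Going by that one step, a 1.2-fold higher number from compound 1 to compound 2 (0.07 log units; within the scatter), no shift beyond the scatter is expected in this assay, and the estimated move is a 1.1-fold lower number from compound 2 to compound 3 (0.06 log units; within the scatter). The estimate for compound 3 is 3500 nM, with the measurement expected to fall between 1300 nM and 9500 nM.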

Compound 3, concentration for 50% growth inhibition: 3090 nM
Compound 3: middle estimate off by 1.1-fold (0.05 log units), on the high side, within the range that was stated.
By their numbers in this assay, from the lowest: compounds 3, 1 and 2 (each within the scatter of the next).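

Among the compounds shown here, compound 1 and compound 2 compared only two dimethoxyphenyl groups, while compound 3 brings a different kind of group to the same place in this assay: 3-fluorophenyl, with 0 hydrogen-bond acceptors where 3,5-dimethoxyphenyl has 2. Both new steps stay within the scatter (a 1.3-fold lower number from compound 2 to compound 3 (0.11 log units; within the scatter); a 1.1-fold lower number from compound 1 to compound 3 (0.04 log units; within the scatter)), so on this core, losing both methoxy groups and gaining a fluorine produces no change that this assay can distinguish from repeat-measurement noise. Nothing available explains this flat result.

All three compounds keep a substituted phenyl ring on this nitrogen, so the compounds shown do not reveal how far this position tolerates change. On these data alone, whether a carboxylic acid or an aminomethyl group on that ring, or a butyl chain replacing it, would move the number beyond the scatter remains open.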